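The source may report more compounds than this note shows. Statements on the series, on what has been measured and on what is new or still open speak of the compounds shown alone.

Compound 1 `C/C(=N\OCC(=O)O)c1ccccc1` is known in a functional assay on the whole organism for inhibition, with Rattus norvegicus as the target, read by paw edema, with stated times of 1 h and 3 h, at a dose of 50 mg/kg by the oral route (a lower number here means less inhibition, a higher number more inhibition at the dose given (going by the name of the read-out)), only as a limit, where compound 1 gives < 20%. Compound 2 `C/C(=N\OCC(=O)O)c1ccccc1O` likewise reaches only a limit, with compound 2 giving < 20%. Compound 3 `C/C(=N\OCC(=O)O)c1cccc(Cl)c1` gives a number, compound 3 showing 20%. Of the measured steps, a step that the two limits leave unreadable from compound 1 to compound 2 and a number no lower from compound 1 to compound 3 (the limit leaves the size open) both start from compound 1, yet neither can be sized because of the limit of < 20% in this assay, at which 2 of the 3 values shown sit. Compound 4 `C/C(=N\OCC(=O)O)c1ccc(CC2CCCCC2)cc1` differs from compound 1 by cyclohexylmethyl in place of hydrogen on an aromatic carbon. Among the measured compounds shown here, no measured step carries this change, and the two steps that start from compound 1 give no readable size, so the expected step in this assay is small and of uncertain direction, a number at least 5 percentage points higher from compound 1 to compound 4 (that floor lies within the scatter). Compound 4 is therefore expected to give about 25%, within 10% to 45%.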

Compound 4, a percentage reported as inhibition, in the whole organism at one dose (the size of the read-out at that dose, not a potency): < 20%
Compound 4 ended at the assay's limit; the forecaster's own chance of this, stated with the estimate: 35%; middle value at least 5 percentage points from the limit.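

Compound 1 and compound 4 both sit at a limit, so no step between them can be read: the limit of < 20% in this assay, at which 3 of the 4 values shown sit.

The compounds shown leave open whether cyclohexylmethyl in place of hydrogen changes the inhibition at all.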